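The source may report more compounds than this note shows. Statements on the series, on what has been measured and on what is new or still open speak of the compounds shown alone.

Measured so far in a functional assay on MT2 cells (Homo sapiens) for cytotoxicity, read by MTT assay; a higher number here means that more compound is tolerated, a lower number that less compound is tolerated:
- compound 1 `CC(C)=CCOc1cccc(Nc2nccs2)c1`: 23000 nM
- compound 2 `CCc1ccc(Nc2nccs2)cc1OCC=C(C)C`: 31000 nM
- compound 3 `Clc1ccc(Nc2nccs2)cc1OCc1ccoc1`: 26000 nM

The value of compound 3 lies within the scatter of both others, so the three stand level. Compound 4 `CC1=C(COc2cc(Nc3nccs3)ccc2Cl)CCC1` has not yet been measured. It differs from compound 3 by 2-methylcyclopent-1-en-1-yl in place of furan-3-yl on a saturated chain carbon bound to an oxygen on an aromatic ring. Among the measured compounds shown here, the only measured single change is a 1.3-fold higher number from compound 1 to compound 2 (0.13 log units; within the scatter). For the measured compounds named here, it stays within the scatter, but it concerns ethyl in place of hydrogen on an aromatic carbon, so no measured step tests this swap directly. A looser hint comes from the side group on that oxygen, which has no aromatic ring in compound 1 at 23000 nM or in compound 2 at 31000 nM. Neither value separates from compound 3. No step beyond the scatter is therefore expected, and the estimated change is a 1.0-fold higher number from compound 3 to compound 4 (0.02 log units; within the scatter). For compound 4 the estimated value is 27000 nM, with an expected range from 14000 nM to 50000 nM.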

Compound 4, half-maximal cytotoxic concentration: 11000 nM
Estimate against measurement, compound 4: 2.5-fold (0.39 log units) above; measured number outside the range, below it.
By their numbers in this assay, from the lowest: compound 4; then compounds 1, 3 and 2 (each within the scatter of the next).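

In this assay, the group carried on the saturated chain carbon bound to an oxygen on an aromatic ring can move the number: 2-methylcyclopent-1-en-1-yl in place of furan-3-yl gives a 2.4-fold lower number from compound 3 to compound 4 (0.37 log units; beyond the scatter) and so less compound is tolerated. Unlike the ethyl in place of hydrogen step, this change lies beyond the scatter, though the step is modest. The swap replaces a five-membered aromatic ring holding an oxygen with a carbon-only, non-aromatic ring bearing a methyl, and nothing available explains the drop.

Because ring type, ring oxygen and methyl all change together, the compounds shown cannot say which of them matters. A phenyl ring, a plain cyclopentyl ring or a dimethylamino group at this place would help separate these features.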